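This account rests on a few compounds, and the source may have more. Where it says the series, first, only, none or still open, it means among the compounds named here.

Compound 1 `COc1cc(C)cc(-c2c(-c3ccnc(-c4ccc(C(C)=O)cc4)c3)cnn2CC#N)c1` was tested in a functional assay on MDA-MB-435 cells (Homo sapiens) for inhibition, read by sulforhodamine B assay, with a stated time of 48 h; a higher number here means a weaker inhibitor of growth, a lower number a stronger inhibitor of growth. In this assay compound 1 gives only the limit > 100000 nM, which is a limit of the assay and not a number (the limit of > 100000 nM in this assay, at which 1 of the 3 values shown sits). Compound 4 `COc1cc(C)cc(-c2c(-c3ccnc(-c4ccc(N(C)C)cc4)c3)cnn2CC#N)c1` keeps the core of compound 1 and differs in one place: dimethylamino in place of acetyl on an aromatic carbon. Among the measured compounds shown here, no measured step matches this change. Compound 2 `COc1cc(C)cc(-c2nn(CC#N)cc2-c2ccnc(-c3ccc(N(C)C)cc3)c2)c1` carries the same dimethylamino group as compound 4, joined to the shared core in a different arrangement, and in this assay compound 2 gives 613 nM. Compound 3 `Cc1cc(O)cc(-c2nn(CC#N)cc2-c2ccnc(-c3ccc(N(C)C)cc3)c2)c1` gives 3210 nM in this assay, and the step of a 5.2-fold higher number from compound 2 to compound 3 (0.72 log units; beyond the scatter) concerns a different place. Compound 4 is therefore expected to give a lower number than compound 1 and to land near 3000 nM, estimated between 300 nM and 40000 nM.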

Compound 4, concentration for total growth inhibition: 66.9 nM
Compound 4: middle estimate off by 45-fold (1.65 log units), on the high side, and the stated range ends above it.
By their numbers in this assay, from the lowest: compound 4; then compound 2; then compound 3. At a limit, above all of these: compound 1.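

Among the compounds shown here, the only earlier step concerned a different place, and this one shows how much the 4-substituted phenyl group matters: in this assay, exchanging 4-acetylphenyl for 4-(dimethylamino)phenyl gives an at least 1400-fold lower number from compound 1 to compound 4 (3.17 log units; beyond the scatter). The two groups that trade places have the same count of heavy atoms and of hydrogen-bond acceptors, yet the outcome differs this widely. The full size of the step stays unknown, as compound 1 carries a limit of the assay and not a number: the limit of > 100000 nM in this assay, at which 1 of the 4 values shown sits.

Going by these compounds, only these two groups appear at this position, so it stays open whether a primary amine or a carboxylic acid there would behave like dimethylamino or like acetyl. These compounds also do not tell why the change has so large an effect.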